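The source may report more compounds than this note shows. Statements on the series, on what has been measured and on what is new or still open speak of the compounds shown alone.

Compound 1 `Cn1c(=O)c(=O)n(C2CCCC2)c2nc(N/N=C/c3cc(C(F)(F)F)c(O)c(C(F)(F)F)c3)ncc21`: 27100 nM
Compound 2 `Cn1c(=O)c(=O)n(C2CCCC2)c2nc(N/N=C/c3cccc(Cl)c3Cl)ncc21`: 26400 nM

In a functional assay on HCT-116 cells (Homo sapiens) for antiproliferative activity, read by MTT assay (on this read-out higher numbers stand for weaker inhibition and lower numbers for stronger inhibition), compound 1 gives 27100 nM, and in this assay compound 2 gives 26400 nM. For the measured compounds named here, compound 2 holds one of only two numbers, and its gap to compound 1 lies within the scatter, so the two are alike. Compound 3 `Cn1c(=O)c(=O)n(C2CCCC2)c2nc(N/N=C/c3cccc([N+](=O)[O-])c3)ncc21` differs from compound 2 by 3-nitrophenyl in place of 2,3-dichlorophenyl on a carbon with a double bond to nitrogen. Going by the values given here, no pair of measured compounds shows this change, so no direction can be drawn from the data. The step from compound 2 to compound 3 is expected to be a 1.1-fold higher number from compound 2 to compound 3 (0.06 log units; within the scatter), that is, none beyond the scatter. Compound 3 is therefore estimated at 30000 nM, with a range from 12000 nM to 75000 nM.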

Compound 3, half-maximal inhibitory concentration: 15200 nM
Beside the measured number, compound 3's estimate is 2.0-fold (0.30 log units) above it; the measured number falls inside the stated range.
By their numbers in this assay, from the lowest: compounds 3, 2 and 1 (each within the scatter of the next).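

In this assay, 3-nitrophenyl in place of 2,3-dichlorophenyl on a carbon with a double bond to nitrogen gives a 1.7-fold lower number from compound 2 to compound 3 (0.24 log units; within the scatter) and thus no shift beyond the scatter. For the compounds shown here, this is the first step that can be read at this position, and it shows that exchanging both chlorine atoms for a nitro group leaves the number within the scatter. Nothing at hand explains the result.

Still open, going by these compounds, is whether an aminophenyl or a carboxyphenyl group at this position would move the number beyond the scatter.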